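Swapping One Amide Group at the Assay Limit

The source may hold more compounds than are shown below. What is called first, only, known or untested is meant among the compounds shown, and "the series" means these compounds.

In a functional assay on MIA PaCa-2 cells (Homo sapiens) for inhibition, read by MTT assay, with a stated time of 3 days (on this read-out higher numbers stand for weaker inhibition and lower numbers for stronger inhibition), compound 1 (`CCN(CC)S(=O)(=O)c1ccc(S(=O)(=O)N2CCC[C@@H](C(=O)N[C@H]3CCOC3)C2)cc1`) reaches only a limit, > 10000 nM. Compound 2 (`CN(C)S(=O)(=O)c1ccc(S(=O)(=O)N2CCC[C@@H](C(=O)N3CCC(F)(F)CC3)C2)cc1`) also reaches only a limit, > 3000 nM. For the measured compounds named here, neither compound gives an exact number, so there is no measured step to learn from.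

Compound 3 (`CCN(CC)S(=O)(=O)c1ccc(S(=O)(=O)N2CCC[C@@H](C(=O)N3CCS(=O)(=O)CC3)C2)cc1`) keeps the core of compound 1 and changes in one place, on a carbonyl carbon, where 1,1-dioxothiomorpholin-4-yl stands in place of (oxolan-3-yl)amino (1,1-dioxothiomorpholin-4-yl in place of (oxolan-3-yl)amino on a carbonyl carbon).

Compound 1 sits at the limit of > 10000 nM, so no change beyond the scatter is expected in this assay for compound 3, which will most likely be reported as a limit too. The estimated step is a number no higher from compound 1 to compound 3 (the limit leaves the size open). For compound 3 the expected value is 10000 nM, with an estimated range from 3000 nM to 30000 nM.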

Compound 3, half-maximal inhibitory concentration: > 10000 nM
Compound 3: only a limit was reported; the forecaster's own chance of this, stated with the estimate: 75%; the middle value lies on the limit itself.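

Compound 1 and compound 3 both stop at a limit, so no step can be read between them: the limit of > 10000 nM in this assay, at which 2 of the 3 values shown sit.

Going by these compounds, whether 1,1-dioxothiomorpholin-4-yl and (oxolan-3-yl)amino on a carbonyl carbon give different results in this assay stays open, as does the exact value of either compound.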